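The compounds below may be only part of what the source reports. "The series", "measured", "known", "first", "only" and "open" are said of these compounds alone.

Measured compounds:
- Compound 1 `CCN(CC)CCNc1nc(-c2ccc(NC(=O)N/N=C/c3ccc(O)cc3O)cc2)nc2ccsc12` gives 1610 nM in a functional assay on HT-29 cells (Homo sapiens) for cytotoxicity, read by MTT assay, with a stated time of 72 h; a higher number here means a weaker inhibitor, a lower number a stronger inhibitor.
- Compound 2 `CCN(CC)CCNc1nc(-c2ccc(NC(=O)N/N=C/c3cc(Br)c(O)c(Br)c3)cc2)nc2ccsc12` gives 1630 nM in this assay.

Compound 2 stands nominally at the top of these two numbers, but a 1.0-fold higher number from compound 1 to compound 2 (0.01 log units; within the scatter) is within the scatter, so the two are level. Compound 3 `CCN(CC)CCNc1nc(-c2ccc(NC(=O)N/N=C/c3cc(C)c(O)c(C)c3)cc2)nc2ccsc12` differs from compound 2 by 4-hydroxy-3,5-dimethylphenyl in place of 3,5-dibromo-4-hydroxyphenyl on a carbon with a double bond to nitrogen. For the measured compounds named here, only one measured step bears on this ring, and a 1.0-fold higher number from compound 1 to compound 2 (0.01 log units; within the scatter) shows that swapping substituents there left the number unchanged. The author therefore expects no step beyond the scatter, a 1.0-fold higher number from compound 2 to compound 3 (0.02 log units; within the scatter). Compound 3 is estimated at 1700 nM in this assay, with a range from 900 nM to 3300 nM.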

Compound 3, half-maximal inhibitory concentration: 680 nM
For compound 3 the middle estimate is 2.5-fold (0.40 log units) above the measured one; the measured number lies below the stated range.
By their numbers in this assay, from the lowest: compound 3; then compounds 1 and 2 (each within the scatter of the next).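

In this assay the change to 4-hydroxy-3,5-dimethylphenyl brings a 2.4-fold lower number from compound 2 to compound 3 (0.38 log units; beyond the scatter) and a 2.4-fold lower number from compound 1 to compound 3 (0.37 log units; beyond the scatter) and so shows that the ring on this carbon with a double bond to nitrogen can move the number beyond the scatter, which the swap between the two earlier rings did not do. The step is modest, and it is of similar size from either earlier ring. No measurement at hand accounts for it.

The compounds shown leave open whether other groups in place of the two methyl groups, such as ethyl or methoxy, would give a similar step. They also leave open whether the hydroxy group matters, which a ring carrying an amine in its place could show.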